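This account rests on a few compounds, and the source may have more. Where it says the series, first, only, none or still open, it means among the compounds named here.

Working notes on the series. In an in vitro functional assay on 1321-N1 cells for agonist activity at P2Y purinoceptor 2 (Homo sapiens), read by scintillation proximity assay and inositol phosphate accumulation (a lower number here means that less compound is needed, a higher number that more compound is needed for the effect), compound 3 `CCCSc1nc(=O)ccn1[C@@H]1O[C@H](COP(=O)(O)OP(=O)(O)O)[C@@H](O)[C@H]1O` gives 1200 nM, the lower of the two numbers recorded so far; the nearest, compound 2 `O=c1ccn([C@@H]2O[C@H](COP(=O)(O)O)[C@@H](O)[C@H]2O)c(SCCc2ccccc2)n1`, lies within the scatter, as compound 2 gives 1300 nM in this assay. Compound 1 `CNc1nc(=O)ccn1[C@@H]1O[C@H](COP(=O)(O)O)[C@@H](O)[C@H]1O` is recorded only as a limit of this assay, > 100000 nM (the limit of > 100000 nM in this assay, at which 1 of the 3 values shown sits).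

The next compound, compound 4 `CNc1nc(=O)ccn1[C@@H]1O[C@H](COP(=O)(O)OP(=O)(O)O)[C@@H](O)[C@H]1O`, differs from compound 3 in one place: methylamino in place of propylsulfanyl on an aromatic carbon. Going by the values given here, one measured step bears on this exchange, run in the opposite direction: an at least 76-fold lower number from compound 1 to compound 2 (1.88 log units; beyond the scatter), a large step beyond the scatter, though it ends at a limit rather than a number. Among the compounds with values here, the chain removed there was phenethylsulfanyl rather than propylsulfanyl, and compound 1 and compound 2 carry a monophosphate where compound 3 and compound 4 carry a diphosphate; no measured step covers either difference, so the size transfers only loosely.

The expectation is therefore a large rise in the number, expected as a 42-fold higher number from compound 3 to compound 4 (1.62 log units; beyond the scatter), with a fair chance that this assay again returns only a limit. Compound 4 is estimated at 50000 nM, expected between 5000 nM and 200000 nM.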

Compound 4, half-maximal effective concentration: 7600 nM
Beside the measured number, compound 4's estimate is 6.6-fold (0.82 log units) above it; the range from low to high includes it.
By their numbers in this assay, from the lowest: compounds 3 and 2 (each within the scatter of the next); then compound 4. At a limit, above all of these: compound 1.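

With the diphosphate held constant, the exchange on this aromatic carbon between two ring nitrogen atoms now has a number at both ends in this assay, as a 6.3-fold higher number from compound 3 to compound 4 (0.80 log units; beyond the scatter), and this step is modest, so methylamino at this position does not by itself put a diphosphate compound at the limit of the assay. With methylamino held constant, the diphosphate in place of the monophosphate gives an at least 13-fold lower number from compound 1 to compound 4 (1.11 log units; beyond the scatter), the first measured sign that the phosphate chain matters in this series as well as the group on this carbon. Compound 1 is a limit, and the size of that step rests on it: the limit of > 100000 nM in this assay, at which 1 of the 4 values shown sits.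

Compound 2 and compound 3 differ in both the sulfanyl chain and the phosphate chain, so the compounds shown do not separate these two changes, and propylsulfanyl with a monophosphate or phenethylsulfanyl with a diphosphate would be needed to do so. Also open, from the compounds shown here alone, is how a butylsulfanyl chain, a dimethylamino group or a triphosphate would read in this assay.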